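Two Inactive Analogs and a Halogen Swap

A few compounds are considered here, and "the series" means these few. Any claim that something is new, unique, unknown or untested is made for them only; others in the source may bear on it.

Compound 1 `Cc1cc(C)cc(-n2nncc2CN2C(=O)C3(C(C#N)=C(N)Oc4c3c3nc5ccccc5nc3c3ccccc43)c3ccccc32)c1`: in a functional assay on HCT-116 cells (Homo sapiens) for antiproliferative activity, read by MTT assay, with a stated time of 48 h (a lower number here means a stronger inhibitor, a higher number a weaker inhibitor), compound 1 gives only a limit, > 50000 nM.
Compound 2 `N#CC1=C(N)Oc2c(N)cc3nc4ccccc4nc3c2C12C(=O)N(Cc1cnnn1-c1ccc(Cl)cc1)c1ccccc12`: in this assay compound 2 gives only a limit, > 50000 nM.

Neither measured compound yields a number in this assay. Among the compounds with values here, compound 2 therefore stands at the limit of the assay, as does the only other value shown, so that the limit of > 50000 nM in this assay, at which 2 of the 2 values shown sit, describes the whole of what is known. Within the data shown here, no step between measured compounds can be computed, since compound 1 and compound 2 differ in more than one place and both sit at the same limit.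

Compound 3 `N#CC1=C(N)Oc2c(N)cc3nc4ccccc4nc3c2C12C(=O)N(Cc1cnnn1-c1ccc(F)c(Cl)c1)c1ccccc12` is the next compound. It differs from compound 2 in one place: 3-chloro-4-fluorophenyl in place of 4-chlorophenyl on an aromatic nitrogen. With compound 2 at the limit in this assay, and the change confined to a single aromatic ring, no step beyond the scatter is expected, and the change from compound 2 to compound 3 is estimated as a step that the limit leaves unreadable from compound 2 to compound 3. Compound 3 is expected to give roughly 70000 nM in this assay, within a range of 25000 nM to 250000 nM, and most likely the assay will again report only a limit rather than a number.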

Compound 3, half-maximal inhibitory concentration: > 50000 nM
Compound 3 ended at the assay's limit; the forecaster's own chance of this, stated with the estimate: 85%; the middle value is on the limit's open side.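

In this assay compound 3 gives > 50000 nM, which is a limit and not a number. Compound 2 also gives only a limit, so no step can be read between compound 2 and compound 3. The compounds shown leave open which structural change, if any, would bring a measurable value in this assay. All of them stand at the same point: the limit of > 50000 nM in this assay, at which 3 of the 3 values shown sit.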